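A few compounds are considered here, and "the series" means these few. Any claim that something is new, unique, unknown or untested is made for them only; others in the source may bear on it.

Compound 1 `COc1ccc(OC)c(/C=C/c2nnc(Nc3ccc(Cl)cc3)o2)c1` carries an oxadiazole core, and in a functional assay on NCI-H226 cells (Homo sapiens) for antiproliferative activity, read by sulforhodamine B assay, with a stated time of 48 h (on this read-out lower numbers stand for stronger inhibition of growth and higher numbers for weaker inhibition of growth), compound 1 gives "not determined" (no result reported), that is, no reported result. Going by the values given here, compound 2 `COc1ccc(OC)c(/C=C/C(=O)N/N=C/c2ccc(Cl)cc2)c1` is the only compound with a number here: in this assay compound 2 gives 979 nM. Compound 3 `COc1ccc(OC)c(/C=C/C(=O)N/N=C/c2ccccc2)c1` differs from compound 2 by hydrogen in place of chloro on an aromatic carbon. Among the compounds with values here, no measured pair shows this change, so the step from compound 2 to compound 3 is expected to be small, probably toward weaker inhibition but possibly not beyond the scatter, a 1.5-fold higher number from compound 2 to compound 3 (0.19 log units; within the scatter). Compound 3 is therefore estimated at 1500 nM, within 500 nM to 4500 nM.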

Compound 3, concentration for 50% growth inhibition: 30800 nM
Compound 3: middle estimate off by 21-fold (1.31 log units), on the low side, and the stated range ends below it.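

In this assay, going by these compounds alone, the chloro on an aromatic carbon para to a large group carries far more weight than the earlier compounds could show: the change from 4-chlorophenyl to phenyl is a large loss of growth inhibition (a 31-fold higher number from compound 2 to compound 3 (1.50 log units; beyond the scatter)). A single heavy atom at this place therefore separates the two compounds clearly. Nothing available explains the size of this step. Going by these compounds, whether a fluoro, a bromo, a methoxy or an amine at this place would match the chloro of compound 2 remains open. On these data alone, whether the chloro matters equally on another carbon of this ring also remains open.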